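Swapping a cyclohexyl tail for an indole on a crown-ether ester

A few compounds are considered here, and "the series" means these few. Any claim that something is new, unique, unknown or untested is made for them only; others in the source may bear on it.

The compounds measured so far:
compound 1, `O=C(CCCCC1CCCCC1)OCC1COCCOCCOCCOCCOCCO1`, 33000 nM
compound 2, `CC(C)=CC1C(C(=O)OCC2COCCOCCOCCOCCOCCO2)C1(C)C`, 56000 nM
compound 3, `O=C(OCC1COCCOCCOCCOCCOCCO1)c1cccc(-c2ccc(Br)cc2)c1`, 6200 nM

All three share a crown-ether core joined through an ester to a different side chain, and all were tested in a functional assay on WiDr cells (Homo sapiens) for inhibition, read by sulforhodamine B assay, with a stated time of 48 h; a lower number here means a stronger inhibitor of growth, a higher number a weaker inhibitor of growth. Compound 1 gives 33000 nM, the second highest of the three numbers. Its nearest neighbour is compound 2, and the move a 1.7-fold higher number from compound 1 to compound 2 (0.23 log units; within the scatter) exchanges one saturated side chain for another. Compound 3, with an aromatic bromobiphenyl side chain, gives 6200 nM, a lower number than compound 1 and beyond the scatter.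

The new compound is compound 4, `O=C(CCCc1cc2ccccc2[nH]1)OCC1COCCOCCOCCOCCOCCO1`. Relative to compound 1 the change is 1H-indol-2-yl in place of cyclohexylmethyl on a saturated chain carbon, three bonds along the chain from a carbonyl carbon. Within the data shown here, only one measured step bears on it, the step from compound 1 to compound 2, and that stayed within the scatter. Among the measured compounds shown here, no measured step replaces a saturated ring with an aromatic one at a single point; the values of compound 1 and compound 3 merely show that the one aromatic side chain in the set carries the lower number. On this slender basis compound 4 is expected to give a somewhat lower number than compound 1, a step of a 1.7-fold lower number from compound 1 to compound 4 (0.22 log units; within the scatter), with wide uncertainty. The estimate for compound 4 in this assay is 20000 nM, within a range from 7000 nM to 60000 nM.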

Compound 4, concentration for 50% growth inhibition: > 100000 nM
Compound 4 was reported as a limit; the forecaster's own chance of this, stated with the estimate: 10%; at least 5.0-fold (0.69 log units) between middle value and limit.
By their numbers in this assay, from the lowest: compound 3; then compounds 1 and 2 (each within the scatter of the next). At a limit, above all of these: compound 4.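

In this assay compound 4 gives > 100000 nM, which is a limit of the assay and not a number. Placing 1H-indol-2-yl where cyclohexylmethyl stood, on a saturated chain carbon three bonds along the chain from a carbonyl carbon, brings an at least 3.0-fold higher number from compound 1 to compound 4 (0.48 log units; beyond the scatter), so this part of the side chain does respond to what is attached; the earlier change in the side chain gave only a 1.7-fold higher number from compound 1 to compound 2 (0.23 log units; within the scatter). An aromatic side chain on the shared core therefore does not by itself go with a lower number: compound 3 had left that impression, and compound 4 goes against it.

The compounds shown cannot say which part of the change matters, since the ring type, the ring size and the hydrogen on the indole nitrogen all change together, and a phenyl group in the same place would begin to separate them. Going by these compounds, it also remains open whether a shorter or longer chain carrying the indole, or an amine at the end of the chain, would bring the number back towards that of compound 1.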